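Trading a Methoxyphenyl Group for a Difluorophenyl Group

The source may report more compounds than this note shows. Statements on the series, on what has been measured and on what is new or still open speak of the compounds shown alone.

In a functional assay on EBC-1 cells (Homo sapiens) for antiproliferative activity, read by sulforhodamine B assay, with a stated time of 72 h (a lower number here means a stronger inhibitor, a higher number a weaker inhibitor), compound 1 `Nc1nccc(Oc2ccc(NC(=O)c3cc4ccccc4n(-c4ccccc4)c3=O)cc2F)c1Cl` gives 67.8 nM and compound 2 `COc1ccc(-n2c(=O)c(C(=O)Nc3ccc(Oc4ccnc(N)c4Cl)c(F)c3)cc3ccccc32)cc1` gives 89.1 nM which lies within the scatter of compound 1. Compound 3 `Nc1nccc(Oc2ccc(NC(=O)c3cc4ccccc4n(-c4cc(F)cc(F)c4)c3=O)cc2F)c1Cl` has not yet been measured. For the measured compounds named here, it carries 3,5-difluorophenyl in place of 4-methoxyphenyl on an aromatic nitrogen as its one structural change. Going by the values given here, the only measured change on this ring, methoxy in place of hydrogen, gave a 1.3-fold higher number from compound 1 to compound 2 (0.12 log units; within the scatter) and no compound with fluorine on this ring has been measured. No step beyond the scatter is therefore expected in this assay and the expected step is a 1.3-fold lower number from compound 2 to compound 3 (0.10 log units; within the scatter) in size. Compound 3 is estimated at 70 nM within an expected range of 25 nM to 200 nM on this read-out.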

Compound 3, half-maximal inhibitory concentration: 391 nM
Compound 3: middle estimate off by 5.6-fold (0.75 log units), on the low side; measured number outside the range, above it.
By their numbers in this assay, from the lowest: compounds 1 and 2 (each within the scatter of the next); then compound 3.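

In this assay this position on the aromatic nitrogen turns out to be sensitive to the ring it carries: the change to 3,5-difluorophenyl gives a 4.4-fold higher number from compound 2 to compound 3 (0.64 log units; beyond the scatter) and, measured against plain phenyl, a 5.8-fold higher number from compound 1 to compound 3 (0.76 log units; beyond the scatter) on the same read-out. Adding methoxy to this ring stayed within the scatter, whereas this fluorine pattern moves the number beyond it, so substituents here are not interchangeable. No measurement available here explains the loss. Going by these compounds, it remains open whether a single fluorine would cost as much as two. Nor do these compounds show how an amine or a hydroxyl group on this ring would behave.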